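This account rests on a few compounds, and the source may have more. Where it says the series, first, only, none or still open, it means among the compounds named here.

Measured so far:
- compound 1, `COc1ccc(OC)c(N2C(=O)CSC2c2cccc(C(=O)NCCCCc3ccccc3)c2)c1`: 2%
- compound 2, `O=C(NCCCCc1ccccc1)c1cccc(C2SCC(=O)N2c2cccc(F)c2)c1`: 63%
- compound 3, `O=C(NCCCCc1ccccc1)c1cccc(C2SCC(=O)N2c2ccccc2F)c1`: 59%

In a functional assay on 143B cells (Homo sapiens) for inhibition, read by CCK-8 assay, with a stated time of 72 h, tested at 1 uM (on this read-out higher numbers stand for more inhibition at the one concentration tested (going by the name of the read-out) and lower numbers for less inhibition), compound 3 stands second highest of the three numbers; its nearest neighbour is compound 2, and the two lie within the scatter of each other, a number 4 percentage points lower from compound 2 to compound 3 (within the scatter). Compound 1 sits far below both, a number 57 percentage points higher from compound 1 to compound 3 (beyond the scatter) and a number 61 percentage points higher from compound 1 to compound 2 (beyond the scatter).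

Compound 4, `COc1ccc(N2C(=O)CSC2c2cccc(C(=O)NCCCCc3ccccc3)c2)c(OC)c1`, differs from compound 3 at the ring nitrogen: 2,4-dimethoxyphenyl in place of 2-fluorophenyl on an amide-type nitrogen in a ring. Among the measured compounds shown here, the step that bears on this change is the one from compound 1 to compound 3, where 2-fluorophenyl in place of 2,5-dimethoxyphenyl gave a large rise. Compound 4 carries a 2,4-dimethoxyphenyl group, close in kind to the group of compound 1, so the reverse direction is expected: a large fall in this assay, roughly undoing the gain seen in a number 57 percentage points higher from compound 1 to compound 3 (beyond the scatter). The step from compound 3 to compound 4 is thus estimated at a number 47 percentage points lower from compound 3 to compound 4 (beyond the scatter). Whether the shift of one methoxy group from one ring position to another alters this cannot be told from the three measured compounds.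

Compound 4 is therefore expected to give about 12% in this assay, within a range of 0% to 40%.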

Compound 4, a percentage reported as inhibition, at one concentration (the size of the read-out at that concentration, not a potency): 53%
Estimate against measurement, compound 4: 41 percentage points below, outside the stated range (above it).
By their numbers in this assay, from the lowest: compound 1; then compounds 4, 3 and 2 (each within the scatter of the next).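

In this assay, a dimethoxyphenyl group on the ring nitrogen does not by itself go with a low number: with 2,4-dimethoxyphenyl in place of 2,5-dimethoxyphenyl there is a number 51 percentage points higher from compound 1 to compound 4 (beyond the scatter) and the whole gap between compound 1 and the other compounds closes. The 2,4-dimethoxyphenyl group also reads level with both fluorophenyl groups, with a number 6 percentage points lower from compound 3 to compound 4 (within the scatter) and a number 10 percentage points lower from compound 2 to compound 4 (within the scatter) as the two comparisons, so at this position the substitution pattern on the ring counts for more here than the kind of substituent, and compound 1 alone goes against the high numbers. Nothing in hand accounts for the gap between the two dimethoxyphenyl compounds.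

Still open, on these data alone, is whether compound 1 is an isolated case or whether other groups on this ring nitrogen, such as a plain phenyl or a phenyl carrying a dimethylamino group, also fall away. All four compounds share the same core and amide chain, so a shorter chain there remains an untested variable, and single-concentration readings give no potency ranking.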